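This account rests on a few compounds, and the source may have more. Where it says the series, first, only, none or still open, it means among the compounds named here.

Measured compounds:
compound 2 `COc1ccc(/C=C\C(=O)O)c(OCc2cn(-c3cccc([N+](=O)[O-])c3)nn2)c1CC=C(C)C`, 43200 nM
compound 3 `COc1ccccc1-n1cc(COc2c(/C=C\C(=O)O)ccc(OC)c2CC=C(C)C)nn1`, 41500 nM
compound 1 `COc1ccc(/C=C\C(=O)O)c(OCc2cn(-c3ccccc3C(=O)N3CCC(O)C3)nn2)c1CC=C(C)C`, "not determined" (no result reported)

Compound 2 and compound 3 carry different aryl groups on the triazole nitrogen of the shared core; in a functional assay on NCI-H322 cells (Homo sapiens) for cytotoxicity, read by MTT assay, with a stated time of 24 h (a higher number here means a weaker inhibitor, a lower number a stronger inhibitor), compound 2 gives 43200 nM and compound 3 gives 41500 nM. Among the compounds with values here, the only step between measured compounds, a 1.0-fold lower number from compound 2 to compound 3 (0.02 log units; within the scatter), shows that exchanging 3-nitrophenyl for 2-methoxyphenyl leaves the number where it was, so compound 3 and compound 2 cannot be told apart on these data. Compound 1 has no number, so it adds nothing here.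

Compound 4 `COc1cccc(-n2cc(COc3c(/C=C\C(=O)O)ccc(OC)c3CC=C(C)C)nn2)c1` differs from compound 3 only in the aryl group: 3-methoxyphenyl in place of 2-methoxyphenyl on an aromatic nitrogen. Within the data shown here, the one step that bears on this kind of change, a 1.0-fold lower number from compound 2 to compound 3 (0.02 log units; within the scatter), is within the scatter, so a step in this assay of no more than the scatter is expected, in no particular direction, as a 1.0-fold higher number from compound 3 to compound 4 (0.01 log units; within the scatter). For compound 4 the expected value in this assay is 42000 nM, with a range from 20000 nM to 90000 nM.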

Compound 4, half-maximal inhibitory concentration: 25200 nM
Compound 4: the middle estimate sits 1.7-fold (0.22 log units) above what was measured; the range from low to high includes it.
By their numbers in this assay, from the lowest: compounds 4, 3 and 2 (each within the scatter of the next).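

Within this assay, the aryl group on the aromatic nitrogen has now been varied in where its methoxy sits, not only in which group it carries: the two compounds have the same atoms, and the exchange gives a 1.6-fold lower number from compound 3 to compound 4 (0.22 log units; within the scatter) for 3-methoxyphenyl in place of 2-methoxyphenyl. With the position on the aryl ring held constant, methoxy in place of nitro gives a 1.7-fold lower number from compound 2 to compound 4 (0.23 log units; within the scatter) and adds a direct comparison of these two groups. Neither step leaves the scatter, so on these data neither change separates the compounds, and no supporting measurement bears on them.

From the compounds shown here alone, whether 4-methoxyphenyl would also stay within the scatter remains open. So does the effect on the number of an aryl group carrying an amine or a carboxylic acid, or of a longer alkyl chain, on that nitrogen.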